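The source may report more compounds than this note shows. Statements on the series, on what has been measured and on what is new or still open speak of the compounds shown alone.

Compound 3 `c1ccc2c(C3CC(c4ccncc4)=NO3)c[nH]c2c1` is the reference point here. In a functional assay on MDA-MB-231 cells (Homo sapiens) for inhibition, read by MTT assay, with a stated time of 48 h (a lower number here means a stronger inhibitor, a higher number a weaker inhibitor), compound 3 gives 19700 nM. Two other compounds share its core. Compound 1 `Cc1[nH]c2ccccc2c1C1CC(c2ccncc2)=NO1` gives 26600 nM, and compound 2 `Clc1ccc(Cn2cc(C3CC(c4ccncc4)=NO3)c3ccccc32)cc1` gives 13700 nM. The number for compound 3 sits between those of its two companions, and all three lie within the usual scatter of one another: the step of a 1.4-fold lower number from compound 1 to compound 3 (0.13 log units; within the scatter) and the step of a 1.4-fold higher number from compound 2 to compound 3 (0.16 log units; within the scatter) are both too small to count as real differences.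

Compound 4 `COc1ccc2[nH]cc(C3CC(c4ccncc4)=NO3)c2c1` has not yet been measured. It differs from compound 3 in one place: methoxy in place of hydrogen on an aromatic carbon. Neither measured step touches this part of the molecule. The step from compound 1 to compound 3 removed a methyl from an aromatic carbon of the five-membered part of the core, and the step from compound 2 to compound 3 removed a 4-chlorobenzyl from the aromatic nitrogen; both stayed within the scatter. The data therefore give no sign that a small change on the core shifts the number much, and a step of about the same size, or none beyond the scatter, is expected for a 1.0-fold higher number from compound 3 to compound 4 (0.01 log units; within the scatter). Compound 4 is estimated at 20000 nM, with a range from 8000 nM to 50000 nM.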

Compound 4, half-maximal inhibitory concentration: > 100000 nM
Compound 4: a limit, no number; the forecaster's own chance of this, stated with the estimate: 5%; middle value at least 5.0-fold (0.69 log units) away from the limit.
By their numbers in this assay, from the lowest: compounds 2, 3 and 1 (each within the scatter of the next). At a limit, above all of these: compound 4.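

Methoxy in place of hydrogen on an aromatic carbon gives an at least 5.0-fold higher number from compound 3 to compound 4 (0.70 log units; beyond the scatter) in this assay and is the only step in this set that lies beyond the scatter. The earlier steps shown here, which concerned a methyl on the five-membered part of the core and a 4-chlorobenzyl on the aromatic nitrogen, suggested that the core tolerates small changes, but this carbon of the six-membered ring, meta to a fused ring and para to a fused ring, shows that this does not hold at every place on it. The value of compound 4 is a limit and not a number, so the step has a known minimum but no known size: the limit of > 100000 nM in this assay, at which 1 of the 4 values shown sits.

As far as these compounds go, whether fluorine, a hydroxy group or an amine on this same carbon would move the number as far remains open, as does whether methoxy on another carbon of that ring would do so. The compounds shown also leave open whether methoxy here would have the same outcome with the methyl of compound 1 or the 4-chlorobenzyl of compound 2 in place.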